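The source may hold more compounds than are shown below. What is called first, only, known or untested is meant among the compounds shown, and "the series" means these compounds.

- compound 1 `COc1ccc2c(/C=C/C(=O)c3cc(N)c(OC)c(OC)c3)c[nH]c2c1`: 186 nM
- compound 2 `COc1ccc2c(/C=C/C(=O)c3cc(N)c(OC)c(OC)c3)cn(C)c2c1`: 198 nM
- compound 3 `COc1cc(C(=O)/C=C/c2c[nH]c3ccccc23)cc(N)c1OC`: not yet measured

In a functional assay on MHCC97H cells (Homo sapiens) for antiproliferative activity, read by MTT assay, with a stated time of 48 h (a higher number here means a weaker inhibitor, a lower number a stronger inhibitor), compound 1 gives 186 nM. For the measured compounds named here, only one comparison exists, a 1.1-fold higher number from compound 1 to compound 2 (0.03 log units; within the scatter), so compound 1 has no real rank of its own among the two numbers.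

The next change is hydrogen in place of methoxy on an aromatic carbon of a six-membered aromatic ring of carbon only, part of a fused or bridged system of two rings.

Going by the values given here, the single measured step, methyl in place of hydrogen on an aromatic nitrogen, concerns a different place and a different kind of change. Among the compounds with values here, it therefore says little about the loss of methoxy, and no measured step speaks to this change directly. Any expectation is thus a judgement with a wide range, and it leans towards a higher number in this assay rather than no change. The expected step is a 4.3-fold higher number from compound 1 to compound 3 (0.63 log units; beyond the scatter). For compound 3 the estimated value is 800 nM, with an expected range of 220 nM to 3500 nM.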

Compound 3, half-maximal inhibitory concentration: 263 nM
Compound 3: middle estimate off by 3.0-fold (0.48 log units), on the high side; low and high end bracket the measured number.
By their numbers in this assay, from the lowest: compounds 1, 2 and 3 (each within the scatter of the next).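

In this assay, hydrogen in place of methoxy on an aromatic carbon gives a 1.4-fold higher number from compound 1 to compound 3 (0.15 log units; within the scatter). For the compounds shown here, this is the first reading at this place, on an aromatic carbon of a six-membered aromatic ring of carbon only, part of a fused or bridged system of two rings, and the earlier step showed only a change on the aromatic nitrogen. For compounds 1 and 3, the methoxy can give way to hydrogen with the two numbers remaining within the scatter of each other, although no data here explain that outcome.

With only methoxy and hydrogen shown at this carbon, it remains open whether a hydroxyl group, a chlorine atom or a longer chain such as ethoxy would stay level with compound 1 or move the number beyond the scatter. From the compounds shown here alone, it also remains open whether hydrogen at this carbon and methyl on the aromatic nitrogen, taken together in one compound, would give a number level with compounds 1, 2 and 3.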